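The compounds below may be only part of what the source reports. "The series", "measured", "known", "first", "only" and "open" are said of these compounds alone.

Compound 1 `COc1ccc2c(O[C@@H]3C[C@H]4C(=O)N[C@]5(C(=O)NS(=O)(=O)C6CC6)C[C@H]5/C=C\CCCCCNC(=O)N4C3)cc(-c3nc(C(C)C)cs3)nc2c1`: 950 nM
Compound 2 `COc1ccc2c(O[C@@H]3C[C@H]4C(=O)N[C@]5(C(=O)NS(=O)(=O)C6CC6)C[C@H]5/C=C\CCCCNC(=O)N4C3)cc(-c3nc(C(C)C)cs3)nc2c1`: 26 nM

In an in vivo ADME assay on the whole organism (strain Sprague-Dawley) for pharmacokinetics, with Rattus norvegicus as the target, at a dose of 10 mg/kg by the oral route (a lower number here means less compound in the circulation, a higher number more compound in the circulation at the dose given), compound 1 gives 950 nM, and compound 2 gives 26 nM. Compound 2 thus stands at the lower of the two numbers, its nearest neighbour compound 1 lying well beyond the scatter above it. Compound 3 `COc1ccc2c(O[C@@H]3C[C@H]4C(=O)N[C@]5(C(=O)NS(=O)(=O)C6CC6)C[C@H]5/C=C\CCCCN(C)C(=O)N4C3)cc(-c3nc(C(C)C)cs3)nc2c1` carries methyl in place of hydrogen on an amide-type nitrogen in a ring. For the measured compounds named here, no step of this kind is known among the measured compounds, so only a guess is possible: a modest rise in this assay seems as likely as no change beyond the scatter. Compound 3 is therefore expected to give 60 nM, between 10 nM and 350 nM, a step of a 2.3-fold higher number from compound 2 to compound 3 (0.36 log units; beyond the scatter).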

Compound 3, maximal plasma concentration: 730 nM
Beside the measured number, compound 3's estimate is 12-fold (1.09 log units) below it; measured number above the stated range.
By their numbers in this assay, from the lowest: compound 2; then compounds 3 and 1 (each within the scatter of the next).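

In this assay, methyl in place of hydrogen on the amide-type nitrogen in the 14-membered ring gives a 28-fold higher number from compound 2 to compound 3 (1.45 log units; beyond the scatter), a large step beyond the scatter. For the compounds shown here, the earlier compounds held no change at this nitrogen, so this is the first sign that this position bears strongly on the read-out. Nothing available gives a reason for the step. The compounds shown leave open whether an ethyl or a cyclopropyl group on this nitrogen would give a similar step. They also leave open whether methyl there would have any such effect in the larger ring of compound 1.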